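Difluoromethoxy to Phenoxy: Expected Shift in Integrin Binding

The compounds below may be only part of what the source reports. "The series", "measured", "known", "first", "only" and "open" are said of these compounds alone.

Measured compounds:
compound 1, `COc1ccc([C@@H](CC(=O)O)NC(=O)[C@@H]2CCN2S(=O)(=O)c2cc(Cl)cc(Cl)c2)cc1`, 0.39 nM; 0.49 nM (2 entries)
compound 2, `O=C(O)C[C@@H](NC(=O)[C@@H]1CCN1S(=O)(=O)c1cc(Cl)cc(Cl)c1)c1ccc(OC(F)F)cc1`, 1.3 nM

Two compounds carry numbers in an assay on RPMI-8866 cells for inhibition of integrin alpha-4/beta-1 (Homo sapiens); a higher number here means a weaker inhibitor, a lower number a stronger inhibitor. Compound 1 has been run twice, as the several entries of compound 1 in this assay, 0.39 nM; 0.49 nM (2 entries) shows, and both entries sit close together. Compound 2 gives a single number, 1.3 nM, and a further entry for it carries no number at all; the number it does have lies above both entries of compound 1 in this assay.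

Compound 3, `O=C(O)C[C@@H](NC(=O)[C@@H]1CCN1S(=O)(=O)c1cc(Cl)cc(Cl)c1)c1ccc(Oc2ccccc2)cc1`, has not yet been measured. It differs from compound 2 in one place: phenyl in place of difluoromethyl on an oxygen on an aromatic ring. The change is a substantial one in size, yet no measured step of this kind is available among these compounds, so the direction cannot be read from data here. The expected step in this assay is a 1.5-fold higher number from compound 2 to compound 3 (0.19 log units; within the scatter), which is taken to be a modest loss, near the edge of the usual scatter, with a wide band of uncertainty on either side. Compound 3 is therefore estimated at 2 nM, with a range from 0.4 nM to 10 nM.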

Compound 3, half-maximal inhibitory concentration: 3.1 nM
Estimate against measurement, compound 3: 1.6-fold (0.19 log units) below, within the range that was stated.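

In this assay, for the compounds shown here, the only step that can be read at this place, on an oxygen on an aromatic ring, is a 2.4-fold higher number from compound 2 to compound 3 (0.38 log units; beyond the scatter). It shows that this place tolerates a six-membered aromatic ring of carbon only, with 6 heavy atoms replacing the 3 of difluoromethyl, at a modest but real cost: compound 3 still gives 3.1 nM, and the step stands beyond the scatter. Repeat entries in this assay can agree closely, although this pair alone gives no reason for the loss, and the one repeat available is this: the several entries of compound 1 in this assay, 0.39 nM; 0.49 nM (2 entries)

The compounds shown leave open whether the loss belongs to the aromatic ring itself or would also appear with a saturated ring such as cyclohexyl, or with a longer chain such as n-butyl, on the same oxygen. They also leave open how an amine or a carboxylic acid carried on the phenyl would move the number, and whether the same change would give a step of this size on any core other than the shared one.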